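Swapping Trifluoromethyl for Methyl: Compound 3 to Compound 4

The compounds below may be only part of what the source reports. "The series", "measured", "known", "first", "only" and "open" are said of these compounds alone.

In a functional assay on HEK293 cells for antagonist activity at Orexin receptor type 2 (Homo sapiens), read by FLIPR and calcium flux (a higher number here means a more potent compound, by a factor of ten per unit of this negative logarithm, a lower number a less potent compound), compound 3 `O=C(c1nc(C(F)(F)F)ccc1-c1ncccn1)N1CC2(CC2)C[C@H]1CNc1ccc(C(F)(F)F)cn1` gives 5, the lowest of the three measured numbers. Compound 2 `Cc1ccc(-c2nccs2)c(C(=O)N2CC3(CC3)C[C@H]2CNc2ccc(C(F)(F)F)cn2)n1` gives 8 and compound 1 `Cc1ccc(-c2ncccn2)c(C(=O)N2CC3(CC3)C[C@H]2CNc2cc(C(F)(F)F)ccn2)n1` gives 8.1, each standing well beyond the scatter above compound 3. Compound 4 `Cc1ccc(-c2ncccn2)c(C(=O)N2CC3(CC3)C[C@H]2CNc2ccc(C(F)(F)F)cn2)n1` differs from compound 3 in one place: methyl in place of trifluoromethyl on an aromatic carbon. For the measured compounds named here, no measured pair isolates this exchange, yet compound 4 otherwise matches compound 1 and compound 2 closely, both of which carry the methyl. A large upward step is therefore expected, a number 3.00 log units higher from compound 3 to compound 4 (beyond the scatter), because compound 1 reaches 8.1 and compound 2 reaches 8. Compound 4 is expected to give 8, within a range from 7.4 to 8.5.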

Compound 4, negative logarithm of the antagonist equilibrium constant: 7.5
Compound 4: the middle estimate sits 0.50 log units above what was measured; low and high end bracket the measured number.
By their numbers in this assay, from the lowest: compound 3; then compound 4; then compounds 2 and 1 (each within the scatter of the next).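

In this assay, for the compounds shown here, the position para to a pyrimidin-2-yl group proves highly sensitive: methyl in place of trifluoromethyl gives a number 2.50 log units higher from compound 3 to compound 4 (beyond the scatter) in the first direct reading of this exchange. Smaller changes elsewhere also register, with pyrimidin-2-yl in place of 1,3-thiazol-2-yl giving a number 0.50 log units lower from compound 2 to compound 4 (beyond the scatter) and 5-(trifluoromethyl)pyridin-2-yl in place of 4-(trifluoromethyl)pyridin-2-yl giving a number 0.60 log units lower from compound 1 to compound 4 (beyond the scatter) in this series. Nothing available explains these steps. From the compounds shown here alone, whether a chlorine atom or an ethyl group at this position would stay nearer the methyl or the trifluoromethyl result remains open.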